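The source may hold more compounds than are shown below. What is called first, only, known or untested is meant among the compounds shown, and "the series" means these compounds.

Measured compounds in a functional assay on HeLa cells (Homo sapiens) for antiproliferative activity, read by MTT assay, with a stated time of 48 h, in the presence of a further agent that is not named here; a lower number here means a stronger inhibitor of growth, a higher number a weaker inhibitor of growth:

Compound 1 `O=C(NOCc1ccccc1)c1cn(-c2ccccc2)nc1-c1ccc(F)cc1`, compound 1 gives 6110 nM.
Compound 2 `O=C(NOCc1ccccc1F)c1cn(-c2ccccc2)nc1-c1ccc(F)cc1`, compound 2 gives 10300 nM.

Among the measured compounds shown here, compound 2 holds the highest of the two numbers in this assay, with compound 1 as its only neighbour; the one step measured so far, a 1.7-fold higher number from compound 1 to compound 2 (0.23 log units; within the scatter), is within the scatter, so the two cannot be ordered.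

Compound 3 `O=C(NOCc1ccccc1Cl)c1cn(-c2ccccc2)nc1-c1ccc(F)cc1` differs from compound 2 in one place: chloro in place of fluoro on an aromatic carbon. For the measured compounds named here, no measured step covers a chloro entering in place of fluoro; the only measured step, a 1.7-fold higher number from compound 1 to compound 2 (0.23 log units; within the scatter), concerns the same aromatic carbon but a different exchange, and it did not move the number beyond the scatter. A single halogen swap at that position therefore gives no ground to expect a shift beyond the scatter in this assay in either direction, and the step of a 1.1-fold lower number from compound 2 to compound 3 (0.06 log units; within the scatter) is expected to stay small.

Compound 3 is estimated at 9000 nM in this assay, within a range of 3000 nM to 30000 nM.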

Compound 3, concentration for 50% growth inhibition: 36400 nM
The estimate for compound 3 lay 4.0-fold (0.61 log units) below the measured number; measured number outside the range, above it.
By their numbers in this assay, from the lowest: compounds 1 and 2 (each within the scatter of the next); then compound 3.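

In this assay this aromatic carbon, ortho to a large group, proves sensitive to which halogen it carries: going from 2-fluorobenzyl to 2-chlorobenzyl gives a 3.5-fold higher number from compound 2 to compound 3 (0.55 log units; beyond the scatter) as a modest loss of growth inhibition, whereas compound 1 and compound 2 could not be ordered. Chloro in place of hydrogen at the same carbon gives a 6.0-fold higher number from compound 1 to compound 3 (0.78 log units; beyond the scatter) and so also moves the number beyond the scatter, showing that a substituent here can weaken growth inhibition and that the fluoro result does not hold for every halogen. Nothing available explains why chloro and fluoro part here, so the difference stands as an observation only.

With only hydrogen, fluoro and chloro at this carbon, the compounds shown cannot say whether the loss continues with a bromo, a methyl or a methoxy group there, or whether any group at this place would lower the number below that of compound 1. Also open, going by these compounds, is whether a chloro elsewhere on the benzyl ring, or an amine at this same carbon, would carry the same penalty.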